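The source may hold more compounds than are shown below. What is called first, only, known or untested is meant among the compounds shown, and "the series" means these compounds.

Compound 2, `Nc1ccccc1NC(=O)/C=C/c1ccc(CSc2ccc(Cl)cc2)cc1`, gives the highest of the three measured numbers in a functional assay on A549 cells (Homo sapiens) for inhibition, read by CCK-8 assay, with a stated time of 72 h, tested at 8 uM (a higher number here means more inhibition of growth at the concentration tested, a lower number less inhibition of growth), with 59.6%. Compound 1, `Nc1ccccc1NC(=O)c1ccc(CSc2ccc(Br)cc2)cc1`, gives 45.7% in this assay, and compound 3, `Nc1ccccc1NC(=O)c1ccc(CSc2ccc(C(F)(F)F)cn2)cc1`, gives 38.9%; both lie beyond the scatter below compound 2. The unmeasured compound 4, `Nc1ccccc1NC(=O)/C=C/c1ccc(CSc2ccc(C(F)(F)F)cn2)cc1`, differs from compound 2 by 5-(trifluoromethyl)pyridin-2-yl in place of 4-chlorophenyl on a sulfur. Among the measured compounds shown here, no step between measured compounds is available for this exact change, but compound 1 and compound 3 carry the same two kinds of aryl group on the sulfur, and compound 1 gives 45.7% while compound 3 gives 38.9%, values that lie within the scatter of each other. On that basis, a small downward step or none beyond the scatter is expected for compound 4, as a number 7.6 percentage points lower from compound 2 to compound 4 (within the scatter). The growth inhibition of compound 4 in this assay is therefore estimated at 52%, with a likely range from 38% to 66%.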

Compound 4, percent growth inhibition at one concentration: 56.5%
Beside the measured number, compound 4's estimate is 4.5 percentage points below it; measured number inside the range.
By their numbers in this assay, from the lowest: compounds 3 and 1 (each within the scatter of the next); then compounds 4 and 2 (each within the scatter of the next).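

In this assay, 5-(trifluoromethyl)pyridin-2-yl in place of 4-chlorophenyl on a sulfur gives a number 3.1 percentage points lower from compound 2 to compound 4 (within the scatter), the first step among these compounds in which this change is the only difference. At this place, on a sulfur whose other neighbour is a saturated chain carbon, an aromatic ring with a hetero atom and a trifluoromethyl group therefore reads the same as the carbon-only ring bearing chlorine, within the usual scatter. Nothing at hand gives a reason why the two groups read alike.

The compounds shown leave open whether this tolerance extends to rings carrying an amine or a carboxylic acid, or to a plain alkyl chain on the sulfur. They also leave open whether the same exchange would read alike on a core other than that of compound 2.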